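Swapping the amine substituent: expected cytotoxicity of compound 4

The source may report more compounds than this note shows. Statements on the series, on what has been measured and on what is new or still open speak of the compounds shown alone.

Compound 1 `O=c1nc(NCc2ccc(F)cc2)oc2c([N+](=O)[O-])cc(C(F)(F)F)cc12` was tested in an ADME assay on Vero cells (Chlorocebus sabaeus) for cytotoxicity, read by MTT assay, with a stated time of 48 h; a higher number here means a weaker inhibitor, a lower number a stronger inhibitor. In this assay compound 1 gives > 64 ug/mL, which is a limit of the assay rather than a number. Compound 2 `O=C1CN(c2cc(=O)c3cc(C(F)(F)F)cc([N+](=O)[O-])c3o2)CCN1CC1CCCCC1` gives 9.73 ug/mL. Compound 3 `O=C1CN(c2cc(=O)c3cc(C(F)(F)F)cc([N+](=O)[O-])c3s2)CCN1CC1CCCCC1` gives > 64 ug/mL, again a limit. Thus compound 1 sits at the limit of > 64 ug/mL in this assay, at which 2 of the 3 values shown sit.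

Compound 4 `CN(Cc1ccccc1)c1nc(=O)c2cc(C(F)(F)F)cc([N+](=O)[O-])c2o1` differs from compound 1 in one place: benzyl(methyl)amino in place of (4-fluorobenzyl)amino on an aromatic carbon. For the measured compounds named here, no step between measured compounds is available for this change, so the step from compound 1 to compound 4 is expected to stay within the scatter, at most a number no higher from compound 1 to compound 4 (the limit leaves the size open). Compound 4 is therefore expected to give about 64 ug/mL, ranging from 30 ug/mL to 120 ug/mL, most likely again as a limit.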

Compound 4, half-maximal inhibitory concentration: 3.84 ug/mL
Beside the measured number, compound 4's estimate is 17-fold (1.22 log units) above it, outside the stated range (below it).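

In this assay, the group on this aromatic carbon of the shared core clearly matters: benzyl(methyl)amino in place of (4-fluorobenzyl)amino gives an at least 16-fold lower number from compound 1 to compound 4 (1.22 log units; beyond the scatter). Even a swap that keeps the benzene ring and the heavy-atom count can therefore move this read-out well beyond the scatter. The full size of the step stays unknown, since compound 1 rests on a limit of the assay: the limit of > 64 ug/mL in this assay, at which 2 of the 4 values shown sit.

The swap removes the fluorine and also replaces the amine hydrogen with a methyl, so the compounds shown cannot tell which change carries the step. Benzylamino, or (4-fluorobenzyl)(methyl)amino, would separate the two.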